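The source may hold more compounds than are shown below. What is called first, only, known or untested is meant among the compounds shown, and "the series" means these compounds.

Working notes on the series. In a functional assay on CHO-K1 cells for antagonist activity at adenosine receptor A2b (Homo sapiens), read by FLIPR and calcium flux (on this read-out lower numbers stand for stronger inhibition and higher numbers for weaker inhibition), compound 1 `Cc1ccc(C(=O)c2nc(NC(=O)c3cccnc3)nc3ccsc23)s1` gives 287 nM. Compound 2 `O=C(c1ccc(Cl)s1)c1nc(NCc2cccnc2)nc2ccsc12` gives 487 nM in this assay. Compound 3 `O=C(c1nccs1)c1nc(NCc2cccnc2)nc2ccsc12` gives 176 nM in this assay, the lowest of the three numbers; the gap to compound 1 lies within the scatter, while the step of a 2.8-fold lower number from compound 2 to compound 3 (0.44 log units; beyond the scatter) lies beyond it.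

Compound 4 `Cc1ccc(C(=O)c2nc(NCc3cccnc3)nc3ccsc23)cc1` is not yet measured. It differs from compound 3 by 4-methylphenyl in place of 1,3-thiazol-2-yl on a carbonyl carbon. For the measured compounds named here, the only measured step at this carbonyl carbon is a 2.8-fold lower number from compound 2 to compound 3 (0.44 log units; beyond the scatter), in which one five-membered aromatic ring with hetero atoms replaced another; no measured step exchanges such a ring for a six-membered aromatic ring of carbon only, so that step informs the expectation only loosely. The compound with the most hydrogen-bond acceptors at this position, compound 3, holds the lowest number, and compound 2 with fewer acceptors there sits higher; on that basis a modest rise in this assay is expected for compound 4, with wide uncertainty. The estimated step of a 2.3-fold higher number from compound 3 to compound 4 (0.36 log units; beyond the scatter) is therefore expected to take compound 4 to about 400 nM in this assay, between 150 nM and 1200 nM.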

Compound 4, half-maximal inhibitory concentration: 215 nM
Compound 4: middle estimate off by 1.9-fold (0.27 log units), on the high side; low and high end bracket the measured number.
By their numbers in this assay, from the lowest: compounds 3, 4, 1 and 2 (each within the scatter of the next, the first and the last beyond it).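

At this carbonyl carbon, 4-methylphenyl in place of 1,3-thiazol-2-yl gives a 1.2-fold higher number from compound 3 to compound 4 (0.09 log units; within the scatter) in this assay, so a six-membered aromatic ring of carbon only, without hydrogen-bond acceptors, is not separated from the five-membered aromatic ring with hetero atoms. Compound 4 therefore goes against the link between hydrogen-bond acceptors at this position and a lower number that compound 2 and compound 3 alone seemed to suggest, and the link does not hold across these three compounds. Instead, 5-chlorothiophen-2-yl stands apart among the three groups compared here, since 4-methylphenyl in its place gives a 2.3-fold lower number from compound 2 to compound 4 (0.36 log units; beyond the scatter) in this assay, alongside the lower number already seen with 1,3-thiazol-2-yl; no measurement on hand explains any of these differences.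

The compounds shown leave open whether the methyl group of compound 4 contributes at all, which an unsubstituted phenyl group at this carbonyl carbon would test, and whether a 4-chlorophenyl group would bring the number up as in compound 2. They also leave open whether an aromatic ring is needed here at all, a question that a saturated ring such as cyclohexyl or a piperidine amide would address.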